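The source may report more compounds than this note shows. Statements on the series, on what has been measured and on what is new or still open speak of the compounds shown alone.

Measured compounds:
compound 1 `COc1cc2c(Nc3ccc(C#N)cc3)ncnc2cc1OCCCN(C)Cc1ccccc1` — in a functional assay on HepG2 cells (Homo sapiens) for antiproliferative activity, read by MTT assay, with a stated time of 72 h (on this read-out lower numbers stand for stronger inhibition and higher numbers for weaker inhibition), compound 1 gives > 100000 nM, a limit of the assay.
compound 2 `COc1cc2c(Nc3ccc(C#N)cc3)ncnc2cc1OCCCN1CCCCC1CCO` — in this assay compound 2 gives > 100000 nM, also a limit of the assay.

Compound 2 therefore stands only at a limit on the numbers shown; the step that the two limits leave unreadable from compound 1 to compound 2 cannot be read, because both of its ends sit at the limit of > 100000 nM in this assay, at which 2 of the 2 values shown sit.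

Compound 3 `COc1cc2c(Nc3ccc(C#N)cc3)ncnc2cc1OCCCN1CCc2ccccc2C1` is not yet measured. Its change from compound 2 is 1,2,3,4-tetrahydroisoquinolin-2-yl in place of 2-(2-hydroxyethyl)piperidin-1-yl on a saturated chain carbon, three bonds along the chain from an oxygen on an aromatic ring. For the measured compounds named here, no measured step bears on this change, and the single measured step is itself unreadable, so no size or direction for this assay can be taken from the data; the two limits make a further limit the most likely outcome.

Compound 3 is expected at about 100000 nM, within 30000 nM to 300000 nM, a step of a number no higher from compound 2 to compound 3 (the limit leaves the size open) estimated only from the limits.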

Compound 3, half-maximal inhibitory concentration: > 100000 nM
Compound 3: only a limit was reported; the forecaster's own chance of this, stated with the estimate: 75%; the middle value lies on the limit itself.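

Compound 3 gives > 100000 nM in this assay, a limit of the assay. No step among compound 1, compound 2 and compound 3 can be read: the limit of > 100000 nM in this assay, at which 3 of the 3 values shown sit.

The compounds shown leave open whether benzyl(methyl)amino, 2-(2-hydroxyethyl)piperidin-1-yl and 1,2,3,4-tetrahydroisoquinolin-2-yl differ at all in this assay.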